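Swapping pyridin-3-yl for 1,3-thiazol-2-yl on compound 2

A few compounds are considered here, and "the series" means these few. Any claim that something is new, unique, unknown or untested is made for them only; others in the source may bear on it.

In an in vitro ADME assay on microsomes from liver (Homo sapiens) for metabolic stability (on this read-out lower numbers stand for slow clearance and higher numbers for fast clearance), compound 1 `O=C(COCc1ccccc1)N1CCN(c2ccc(F)cc2F)CC1` gives 580 mL.min-1.g-1 as its clearance, while compound 2 `O=C(COCc1cccnc1)N1CCN(c2ccc(Cl)cc2Cl)CC1` gives 210 mL.min-1.g-1 as its clearance. Compound 2 thus holds the lower of the two numbers, and its gap to compound 1 lies beyond the usual scatter. Compound 3 `O=C(COCc1nccs1)N1CCN(c2ccc(Cl)cc2Cl)CC1` differs from compound 2 by one change (1,3-thiazol-2-yl in place of pyridin-3-yl on a saturated chain carbon bound to an oxygen on a saturated carbon): 1,3-thiazol-2-yl stands in place of pyridin-3-yl on a saturated chain carbon bound to an oxygen on a saturated carbon. Going by the values given here, no measured pair shows this change on its own, so the expectation starts from compound 2 at 210 mL.min-1.g-1 and little else. An estimated small rise a 1.2-fold higher number from compound 2 to compound 3 (0.08 log units; within the scatter) would stay within the usual scatter. In this assay the value estimated for compound 3 is 250 mL.min-1.g-1 within an expected range of 110 mL.min-1.g-1 to 550 mL.min-1.g-1 for now.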

Compound 3, intrinsic clearance in microsomes: 80 mL.min-1.g-1
Compound 3: the middle estimate sits 3.1-fold (0.49 log units) above what was measured; the measured number lies below the stated range.
By their numbers in this assay, from the lowest: compound 3; then compound 2; then compound 1.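

Replacing pyridin-3-yl with 1,3-thiazol-2-yl on a saturated chain carbon bound to an oxygen on a saturated carbon gives a 2.6-fold lower number from compound 2 to compound 3 (0.42 log units; beyond the scatter) in this assay with the rest of the molecule unchanged. Going by these compounds alone, compound 1 and compound 2 differ in more than one place, so this step is the first reading of this position on its own. It shows that the number responds to the aromatic ring held at this place, and that a five-membered ring with a sulfur can stand there. Nothing at hand explains why the number falls with this change.

The change alters ring size and hetero atoms together, so the compounds shown cannot separate the two, and a 1,3-oxazol-2-yl group at this place would bear on that. From the compounds shown here alone, it also remains open whether the same swap would lower the number on the difluorophenyl-bearing side of compound 1.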